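The source may hold more compounds than are shown below. What is called first, only, known or untested is meant among the compounds shown, and "the series" means these compounds.

Of the compounds shown here, three built on one shared core have been measured in a functional assay on CHO cells for antagonist activity at Orexin receptor type 2 (Homo sapiens), read by fluorescence and calcium flux, with a stated time of 30 min; a lower number here means a stronger inhibitor, a higher number a weaker inhibitor. Compound 1 `CCN(CCn1ccc(-c2cc(C(F)(F)F)ccn2)n1)C(=O)c1cc(C)ccc1-n1nccn1` gives 66.4 nM, compound 2 `CCN(CCn1ccc(-c2cccc(C(F)(F)F)n2)n1)C(=O)c1cc(C)ccc1-n1nccn1` gives 3.92 nM, and compound 3 `Cc1ccc(-n2nccn2)c(C(=O)N(C)CCn2ccc(-c3ccc(F)cn3)n2)c1` gives 8.58 nM. Among these three numbers compound 3 sits second highest: compound 2 is its nearest neighbour with the lower number, and compound 1 lies furthest from it with the higher number. Going by the values given here, the only step between two compounds that differ in a single place is a 17-fold lower number from compound 1 to compound 2 (1.23 log units; beyond the scatter), and it concerns the trifluoromethyl-bearing pyridinyl group, not the amide nitrogen. Compound 4 `Cc1ccc(-n2nccn2)c(C(=O)N(CCn2ccc(-c3ccc(F)cn3)n2)C(C)C)c1` differs from compound 3 by isopropyl in place of methyl on an amide-type nitrogen. Among the compounds with values here, no measured step changes the group on this nitrogen; compounds 1 and 2 carry ethyl there and compound 3 methyl, but those pairs differ in more than one place, so only their values can be set side by side. With nothing bearing directly on the change, a step in this assay of about a 1.0-fold higher number from compound 3 to compound 4 (0.02 log units; within the scatter) is expected, within the usual scatter. Compound 4 is therefore estimated at 9 nM, between 3 nM and 30 nM.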

Compound 4, antagonist equilibrium constant: 37.9 nM
Beside the measured number, compound 4's estimate is 4.2-fold (0.62 log units) below it, outside the stated range (above it).
By their numbers in this assay, from the lowest: compound 2; then compound 3; then compounds 4 and 1 (each within the scatter of the next).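

In this assay, isopropyl in place of methyl on the amide-type nitrogen gives a 4.4-fold higher number from compound 3 to compound 4 (0.65 log units; beyond the scatter) and so makes compound 4 the weaker inhibitor. Going by these compounds alone, this is the first direct reading at this position, where the earlier compounds could only be set side by side, and it shows that the group on this nitrogen matters: on this core, the larger of these two groups costs potency. The compounds shown hold no measurement that explains this step.

Going by these compounds, how ethyl, a longer chain such as propyl, or a chain ending in an amine would read on this nitrogen in the core of compound 3 remains open. Also open, on these data alone, is whether the same change from methyl to isopropyl would give a step of similar size with a trifluoromethyl-bearing pyridinyl group in the molecule.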